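Trimming the tail of a ghrelin receptor agonist

A few compounds are considered here, and "the series" means these few. Any claim that something is new, unique, unknown or untested is made for them only; others in the source may bear on it.

Three compounds share one core and differ only in the group carried on the saturated chain carbon bound to an aromatic nitrogen of the tetrazole-like ring. Compound 1 `CC(C)(N)C(=O)N[C@H](COCc1ccccc1)c1nnn(Cc2cccc(NS(C)(=O)=O)c2)n1` gives 868 nM in a functional assay on H4 cells for agonist activity at growth hormone secretagogue receptor type 1 (Homo sapiens), read by FLIPR (on this read-out lower numbers stand for an effect already at smaller amounts and higher numbers for an effect only at larger amounts of compound), the highest of the three numbers. Compound 2 `CC(C)(N)C(=O)N[C@H](COCc1ccccc1)c1nnn(CC2Cc3ccccc3N2S(C)(=O)=O)n1` gives 546 nM in this assay, a value within the usual scatter of that of compound 1. Compound 3 `CC(C)(N)C(=O)N[C@H](COCc1ccccc1)c1nnn(CCCc2ccccc2NS(C)(=O)=O)n1` gives 107 nM in this assay, clearly lower than compound 1.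

Compound 4 `CC(C)(N)C(=O)N[C@H](COCc1ccccc1)c1nnn(CC#N)n1` has not been measured. Compared with compound 1 it carries cyano in place of 3-(methanesulfonamido)phenyl on a saturated chain carbon bound to an aromatic nitrogen. All three measured compounds keep a methanesulfonamide-bearing aromatic ring at this position, so nothing measured here shows what happens when that ring is taken away altogether. The change is large in size, and the expectation is a weaker compound: the step from compound 1 to compound 4 is estimated at a 5.8-fold higher number from compound 1 to compound 4 (0.76 log units; beyond the scatter). Compound 4 is accordingly estimated at 5000 nM, with a range from 1500 nM to 20000 nM.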

Compound 4, half-maximal effective concentration: 1520 nM
Compound 4: middle estimate off by 3.3-fold (0.52 log units), on the high side; the measured number falls inside the stated range.
By their numbers in this assay, from the lowest: compound 3; then compounds 2, 1 and 4 (each within the scatter of the next, the first and the last beyond it).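

Replacing 3-(methanesulfonamido)phenyl with cyano on a saturated chain carbon bound to an aromatic nitrogen gives a 1.8-fold higher number from compound 1 to compound 4 (0.24 log units; within the scatter) in this assay. Compound 4 thus shows that this position tolerates the loss of the entire aromatic ring and its methanesulfonamide: a far smaller group leaves the number indistinguishable from that of compound 1. No supporting data are available to explain this result.

This single pair cannot show whether cyano itself helps or whether the core alone accounts for the activity seen in both compounds. Placing a hydrogen, a methyl, a primary amine or a carboxylic acid at this position would test that, and it remains open how any of them would read out.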